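From 3-methoxyphenyl to cyclohexyl in an antiproliferative series

This account rests on a few compounds, and the source may have more. Where it says the series, first, only, none or still open, it means among the compounds named here.

Three compounds have been examined in a functional assay on HCT-116 cells (Homo sapiens) for antiproliferative activity, read by MTT assay, with a stated time of 72 h; a higher number here means a weaker inhibitor, a lower number a stronger inhibitor. Compound 1 (`COc1ccc(N2C(=O)COc3ccc(-c4ccc(O)cc4)cc32)cc1`) gives 26100 nM and compound 2 (`COc1ncc(-c2ccc3c(c2)N(c2ccccc2)C(=O)CO3)cc1NS(=O)(=O)c1ccc(F)cc1`) gives 18800 nM, two values that lie within the usual scatter of each other. Compound 3 (`COc1cccc(N2C(=O)COc3ccc(-c4cccc(NS(=O)(=O)c5ccc(F)cc5)c4)cc32)c1`) gives > 40000 nM, which is a limit of the assay and not a number.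

The next step starts from compound 3. Compound 4 (`O=C1COc2ccc(-c3cccc(NS(=O)(=O)c4ccc(F)cc4)c3)cc2N1C1CCCCC1`) carries cyclohexyl in place of 3-methoxyphenyl on an amide-type nitrogen in a ring, three ring bonds from the ring oxygen: cyclohexyl in place of 3-methoxyphenyl on an amide-type nitrogen in a ring. The rest of the structure stays the same.

No measured pair among these compounds isolates a change at this place, so the expectation has little to lean on. The starting point is compound 3 alone, whose > 40000 nM is again only a limit. In this assay, no step beyond the scatter is expected in either direction, and compound 4 may also return only a limit. The expected change is an at least 1.1-fold lower number from compound 3 to compound 4 (0.05 log units; that floor lies within the scatter), an estimate set against a limit rather than a number. Compound 4 is expected at about 35000 nM, with an estimated range from 15000 nM to 70000 nM.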

Compound 4, half-maximal inhibitory concentration: 18300 nM
Compound 4: middle estimate off by 1.9-fold (0.28 log units), on the high side; low and high end bracket the measured number.
By their numbers in this assay, from the lowest: compounds 4, 2 and 1 (each within the scatter of the next). At a limit, above all of these: compound 3.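

In this assay, cyclohexyl in place of 3-methoxyphenyl on the amide-type nitrogen in a ring brings an at least 2.1-fold lower number from compound 3 to compound 4 (0.33 log units; beyond the scatter), the first step at this place among the compounds shown. With a non-aromatic ring of carbon only on this nitrogen, compound 4 gives 18300 nM, a number and not a limit, so the position responds to the change in this assay. Compound 3 stands at a limit of the assay, so the step has only a floor and its full size cannot be read: the limit of > 40000 nM in this assay, at which 1 of the 4 values shown sits.

The change removes the aromatic ring and the methoxy group together, so the compounds shown leave open which of the two accounts for the step, and an unsubstituted phenyl or a methoxy-bearing cyclohexyl on this nitrogen would be needed to separate them. Also open, going by these compounds, is how a methyl group, a longer alkyl chain or a piperidine ring would read at this position, and whether cyclohexyl brings a similar step when the rest of the structure is that of compound 1 or compound 2.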